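This account rests on a few compounds, and the source may have more. Where it says the series, first, only, none or still open, it means among the compounds named here.

Measured compounds:
- compound 1 `O=C(O)[C@@H]1CCCN1C(=O)CN(c1nc(Cl)nc2[nH]cnc12)C1CC1` — 7.29%
- compound 2 `NCCCC[C@H](NC(=O)CN(c1nc(Cl)nc2[nH]cnc12)C1CC1)C(=O)OCc1ccccc1` — 9.88%
- compound 3 `CC(C)[C@H](NC(=O)CN(c1ncnc2c1ncn2C1CCCCO1)C1CC1)C(=O)OCc1ccccc1` — 21.1%

In a functional assay on the whole organism (Tail, strain ICR) with Mus musculus as the target, in the tail flick test, with a stated time of 150 min, at a dose of 25 umol/kg by the oral route (on this read-out higher numbers stand for a stronger effect at the one dose given and lower numbers for a weaker effect), compound 3 gives 21.1%, the highest of the three numbers. Compound 2 lies beyond the scatter below it, and compound 1 is furthest away, also beyond the scatter. Compound 4 `C[C@H](NC(=O)CN(c1ncnc2c1ncn2C1CCCCO1)C1CC1)C(=O)OCc1ccccc1` has not yet been measured. It differs from compound 3 in one place: methyl in place of isopropyl on a saturated chain carbon bound to an amide-type nitrogen and a carbonyl carbon. Among the measured compounds shown here, no pair of measured compounds shows a step of this kind, so the size of its effect in this assay is unknown. The expectation is that the step from compound 3 to compound 4 stays small, of the order of the scatter, with a slight lean downward. Compound 4 is therefore estimated at 15%, with a range from 4% to 28%, and the estimated step of a number 6.1 percentage points lower from compound 3 to compound 4 (within the scatter) is expected.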

Compound 4, a percentage reported as activity, at one dose (the size of the read-out at that dose, not a potency): 6.01%
Beside the measured number, compound 4's estimate is 9 percentage points above it, and the stated range covers the measured number.
By their numbers in this assay, from the lowest: compounds 4, 1 and 2 (each within the scatter of the next); then compound 3.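

Under this assay methyl in place of isopropyl on a saturated chain carbon bound to an amide-type nitrogen and a carbonyl carbon gives a number 15.1 percentage points lower from compound 3 to compound 4 (beyond the scatter) as the first step measured at this position. The read-out at this one dose therefore responds to the group held there, at least between these two groups. Nothing available gives a reason for the drop. As far as these compounds go, it remains open whether isobutyl or a cyclohexyl ring at this carbon would raise the number further or lower it. A single step also cannot show whether the number follows the size of the chain.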